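The source may hold more compounds than are shown below. What is called first, only, known or untested is meant among the compounds shown, and "the series" means these compounds.

For the measured compounds named here, compound 1 `Cc1ccccc1COc1ccc(N2CCC[C@H]2CC(=O)O)cc1` is the only compound here with a number rather than a limit: in a functional assay on cells for agonist activity at Free fatty acid receptor 1 (Homo sapiens), read by FLIPR and calcium flux, with a stated time of 100 s (a higher number here means that more compound is needed for the effect, a lower number that less compound is needed), compound 1 gives 190 nM. Compound 2 `Cc1ccccc1COc1ccc(N2CCC[C@H]2CC(=O)O)cc1C` differs by a methyl in place of a hydrogen on an aromatic carbon, and in this assay compound 2 reaches only a limit, > 33000 nM. Going by these compounds, that single measured step, an at least 170-fold higher number from compound 1 to compound 2 (2.23 log units; beyond the scatter), is large but sits at the limit (the limit of > 33000 nM in this assay, at which 1 of the 2 values shown sits), so its true size is unknown.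

Compound 3 `O=C(O)C[C@@H]1CCCN1c1ccc(Oc2ccccc2F)cc1` is not yet measured. It differs from compound 1 in one place: 2-fluorophenyl in place of 2-methylbenzyl on an oxygen on an aromatic ring. Going by the values given here, no measured step touches this position, and the step from compound 1 to compound 2 concerns a methyl on an aromatic carbon, not the group on the oxygen, so it gives no direct guidance. Replacing a benzyl group by a phenyl group shortens the link between the two aromatic rings, and such a change is expected to cost some activity. Compound 3 is therefore estimated at 1500 nM, within 300 nM to 8000 nM, which would mean an expected step of a 7.9-fold higher number from compound 1 to compound 3 (0.90 log units; beyond the scatter).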

Compound 3, half-maximal effective concentration: 150 nM
Beside the measured number, compound 3's estimate is 10-fold (1.00 log units) above it; measured number below the stated range.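

In this assay, the group on this oxygen can be exchanged with no change that stands out from the scatter: a 1.3-fold lower number from compound 1 to compound 3 (0.10 log units; within the scatter). The position therefore accepts 2-fluorophenyl as well as 2-methylbenzyl, even though the two groups differ in their atoms, with 7 heavy atoms including a fluorine against 8 carbons, and the earlier step concerned a different place on the molecule. Nothing available here explains why these two groups give such similar numbers.

This single swap alters both the substituent on the ring and the group that links the ring to the oxygen, so the two changes cannot be told apart. Going by these compounds, what a plain phenyl, a plain benzyl or a longer chain on this oxygen would give remains open.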